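Methoxy in place of phenoxy on the aryl ring

This account rests on a few compounds, and the source may have more. Where it says the series, first, only, none or still open, it means among the compounds named here.

Measured so far:
compound 1, `O=c1c2cc([N+](=O)[O-])cnc2sn1-c1ccc([N+](=O)[O-])cc1`, 15800 nM
compound 2, `O=c1c2cc([N+](=O)[O-])cnc2sn1-c1ccc(Br)cc1`, 860 nM
compound 3, `O=c1c2cc([N+](=O)[O-])cnc2sn1-c1ccc(Oc2ccccc2)cc1`, "not determined" (no result reported)

The series shares one core and varies the group on the pendant aryl ring. In an assay for inhibition of histone acetyltransferase KAT2B (Homo sapiens), read by fluorescence (a lower number here means a stronger inhibitor, a higher number a weaker inhibitor), compound 1 gives 15800 nM, and compound 2 gives 860 nM. Among the measured compounds shown here, the one step between them, an 18-fold lower number from compound 1 to compound 2 (1.26 log units; beyond the scatter), is the only measured change in the set. Compound 3 carries a phenoxy group, and in this assay compound 3 gives "not determined" (no result reported), so it stands nowhere on the numbers; it is an open point.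

Compound 4, `COc1ccc(-n2sc3ncc([N+](=O)[O-])cc3c2=O)cc1`, differs from compound 3 by methyl in place of phenyl on an oxygen on an aromatic ring. For the measured compounds named here, no measured step touches the oxygen-linked group: the step from nitro to bromo concerns a different position and a different kind of change, so it gives no direct guide to the size or direction of this one. With compound 3 unmeasured, the estimate for compound 4 can rest only on the span set by compound 1 and compound 2, and is therefore wide. Compound 4 is expected to give about 3000 nM in this assay, within a range of 500 nM to 20000 nM.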

Compound 4, half-maximal inhibitory concentration: 1830 nM
For compound 4 the middle estimate is 1.6-fold (0.21 log units) above the measured one, within the range that was stated.
By their numbers in this assay, from the lowest: compound 2; then compound 4; then compound 1.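

In this assay, among the compounds shown here, methoxy gives a first reading for an oxygen-linked group on the aryl ring, with a 2.1-fold higher number from compound 2 to compound 4 (0.33 log units; beyond the scatter) and with an 8.6-fold lower number from compound 1 to compound 4 (0.94 log units; beyond the scatter). Among the three compounds with numbers, the methoxy compound therefore sits between the bromo and nitro compounds, much nearer the bromo compound, and both new steps lie beyond the scatter. Nothing available here accounts for this order.

From the compounds shown here alone, the step from compound 3 to compound 4 cannot be read, so the effect of replacing phenoxy with methoxy stays unknown, as does whether a larger group on the oxygen helps or harms. Going by these compounds, how an amine or a carboxylic acid in place of methoxy on the aryl ring would compare also remains open.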